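The source may hold more compounds than are shown below. What is called first, only, known or untested is meant among the compounds shown, and "the series" means these compounds.

Measured so far:
Compound 1 `O=C(c1ccc2c(c1)CCCC2)C1CCN(Cc2coc(-c3ccc(F)cc3)n2)CC1` gives > 150 ug/mL in an ADME assay on HEK293 cells (Homo sapiens) for cytotoxicity, read by MTT assay, with a stated time of 36 h (a lower number here means a stronger inhibitor, a higher number a weaker inhibitor), which is a limit of the assay rather than a number.
Compound 2 `Cc1ccc(C(=O)C2CCN(Cc3coc(-c4ccc(F)cc4)n3)CC2)cc1C` gives > 150 ug/mL in this assay, again a limit rather than a number.

Compound 2 therefore stands at the limit of the assay, where both values shown sit (the limit of > 150 ug/mL in this assay, at which 2 of the 2 values shown sit); nothing places it higher or lower than compound 1. For the measured compounds named here, the single measured step, a step that the two limits leave unreadable from compound 1 to compound 2, is left unreadable by the two limits, so it has no size that could be carried over. Compound 3 `Cc1ccc(C(=O)C2CCN(Cc3coc(-c4ccc(F)cc4)n3)CC2)cc1` differs from compound 2 by hydrogen in place of methyl on an aromatic carbon. No measured step bears readably on this change, and the measured compounds give no reason to expect a move away from the limit. The step that the limit leaves unreadable from compound 2 to compound 3 is expected to be none beyond the scatter in this assay. Compound 3 is estimated at 200 ug/mL, within 100 ug/mL to 400 ug/mL, most likely reported once more as a limit.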

Compound 3, half-maximal inhibitory concentration: > 150 ug/mL
Compound 3: only a limit was reported; the forecaster's own chance of this, stated with the estimate: 85%; the middle value does not contradict the limit.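

For the compounds shown here, compound 1, compound 2 and compound 3 all stop at the same limit of the assay, so no step among them can be read: the limit of > 150 ug/mL in this assay, at which 3 of the 3 values shown sit. Going by these compounds, what true value each would give in this assay stays open, as does whether any change to the shared core would give a readable number.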